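A few compounds are considered here, and "the series" means these few. Any claim that something is new, unique, unknown or untested is made for them only; others in the source may bear on it.

Of the compounds shown here, three that share one core have so far been measured in an assay on isolated protein for binding affinity to Gonadotropin-releasing hormone receptor (Homo sapiens); on this read-out higher numbers stand for weaker inhibition and lower numbers for stronger inhibition. Compound 1 `Cc1cc2c(cc1Cc1ccc(C(=O)NCC3CCCCC3)o1)C(C)(C)CCC2(C)C` gives 180 nM. Compound 2 `Cc1cc2c(cc1Cc1ccc(C(=O)NC[C@H]3CC[C@H](C(N)=O)CC3)o1)C(C)(C)CCC2(C)C` gives 13 nM. Compound 3 `Cc1cc2c(cc1Cc1ccc(C(=O)NCc3ccccc3)o1)C(C)(C)CCC2(C)C` gives 102 nM, the second highest of the three numbers: the step of a 1.8-fold lower number from compound 1 to compound 3 (0.25 log units; within the scatter) does not separate these two compounds, whereas the step of a 7.8-fold higher number from compound 2 to compound 3 (0.89 log units; beyond the scatter) clearly does.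

Compound 4 `Cc1cc2c(cc1Cc1ccc(C(=O)NCC3CCCC(CN)C3)o1)C(C)(C)CCC2(C)C` has not been measured yet. It differs from compound 3 in one place: 3-(aminomethyl)cyclohexyl in place of phenyl on a saturated chain carbon bound to an amide-type nitrogen. In words, 3-(aminomethyl)cyclohexyl takes the place of phenyl on a saturated chain carbon bound to an amide-type nitrogen. For the measured compounds named here, two measured steps bear on this. Exchanging phenyl for cyclohexyl, a 1.8-fold lower number from compound 1 to compound 3 (0.25 log units; within the scatter), stayed within the scatter, so the ring exchange by itself should change little. Placing carbamoyl on a saturated ring carbon, a 14-fold lower number from compound 1 to compound 2 (1.14 log units; beyond the scatter), lowered the number by a large step. Going by the values given here, the entering group likewise adds a nitrogen-bearing substituent to a saturated ring, though not the same substituent as in compound 2, and no measured compound carries an aminomethyl, so the size is uncertain. A step of a 2.6-fold lower number from compound 3 to compound 4 (0.41 log units; beyond the scatter) toward a lower number is therefore expected. For compound 4 the value expected in this assay is 40 nM, within a range from 12 nM to 130 nM.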

Compound 4, inhibition constant: 174 nM
The estimate for compound 4 lay 4.4-fold (0.64 log units) below the measured number; measured number above the stated range.
By their numbers in this assay, from the lowest: compound 2; then compounds 3, 4 and 1 (each within the scatter of the next).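

In this assay, aminomethyl in place of hydrogen on a saturated ring carbon gives no step beyond the scatter (a 1.0-fold lower number from compound 1 to compound 4 (0.01 log units; within the scatter)), and 3-(aminomethyl)cyclohexyl in place of phenyl on the saturated chain carbon bound to the amide-type nitrogen also stays within it (a 1.7-fold higher number from compound 3 to compound 4 (0.23 log units; within the scatter)). A nitrogen-bearing substituent on this saturated ring therefore does not by itself lower the number, while the large step between the two substituted rings (a 13-fold higher number from compound 2 to compound 4 (1.13 log units; beyond the scatter)) shows that the choice of substituent and its place on the ring matter here, with 4-carbamoylcyclohexyl giving way to 3-(aminomethyl)cyclohexyl. Nothing available explains the difference between these two groups.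

The step between these two rings changes the group and its ring position together, so it leaves open which of the two accounts for the difference. A 4-(aminomethyl)cyclohexyl or a 3-carbamoylcyclohexyl group would separate these two changes, and a carboxylic acid at either ring position would test whether the lower number depends on the carbamoyl group itself.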